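From 3-aminophenyl to 4-methylphenyl on the shared core

The compounds below may be only part of what the source reports. "The series", "measured", "known", "first", "only" and "open" are said of these compounds alone.

In a functional assay on U-937 cells (Homo sapiens) for cytotoxicity, read by MTT assay, with a stated time of 48 h (a lower number here means a stronger inhibitor, a higher number a weaker inhibitor), compound 1 `COc1ccc(Nc2nc(-c3cccc(F)c3)nc3ccc(F)cc23)cc1` gives 41100 nM, the only measured result that is a true number. Compound 2 `Fc1cccc(-c2nc(Nc3cccc(Br)c3)c3cc(F)ccc3n2)c1` reads > 50000 nM, which is a limit of the assay and not a number. Compound 3 `Nc1cccc(Nc2nc(-c3cccc(F)c3)nc3ccc(F)cc23)c1` reads > 50000 nM, which is likewise a limit. Compound 3 therefore stands at the limit of > 50000 nM in this assay, at which 2 of the 3 values shown sit, and its true position is not known.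

Compound 4 `Cc1ccc(Nc2nc(-c3cccc(F)c3)nc3ccc(F)cc23)cc1` carries 4-methylphenyl in place of 3-aminophenyl on a nitrogen on an aromatic ring.

Two measured steps change this same place: an at least 1.2-fold higher number from compound 1 to compound 2 (0.08 log units; that floor lies within the scatter) and an at least 1.2-fold higher number from compound 1 to compound 3 (0.08 log units; that floor lies within the scatter). Each gives only a floor, and both floors lie within the scatter. The remaining step, a step that the two limits leave unreadable from compound 2 to compound 3, changes a group on the ring and cannot be sized. None of these steps shows a change beyond the scatter, so no large step is expected in this assay. At most a small move towards a lower number is anticipated, based on compound 1 at 41100 nM, which bears 4-methoxyphenyl at this place. The expected change is an at least 1.1-fold lower number from compound 3 to compound 4 (0.07 log units; that floor lies within the scatter). Compound 4 is estimated at 42000 nM, with an expected range from 22000 nM to 50000 nM.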

Compound 4, half-maximal inhibitory concentration: > 50000 nM
Compound 4: no number, only a limit; the forecaster's own chance of this, stated with the estimate: 45%; middle value at least 1.1-fold (0.07 log units) away from the limit.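

In this assay compound 4 joins compound 2 and compound 3 at one and the same reading, which is a limit of the assay and not a number: the limit of > 50000 nM in this assay, at which 3 of the 4 values shown sit.

Among these compounds, the one step that can be read, with methyl in place of methoxy on an aromatic carbon, is an at least 1.2-fold higher number from compound 1 to compound 4 (0.08 log units; that floor lies within the scatter), so it gives only a floor and does not separate the two compounds; the steps to compound 4 from compound 2 and from compound 3 cannot be read, since both ends are limits. Among the compounds shown here, what the result adds is that 4-methylphenyl, with no hydrogen-bond donor or acceptor, reaches the same limit as 3-aminophenyl and 3-bromophenyl, which leaves 4-methoxyphenyl in compound 1 as the only group at this position with a true number.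

From the compounds shown here alone, how far the true values of compound 2, compound 3 and compound 4 lie past the limit remains unknown, and so does any order among them. Going by these compounds, it also remains open whether a carboxylic acid or a longer chain on this phenyl ring would give a true number in this assay.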